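Trimming the Side Chain of a Bridged Diphenyl Amine

The compounds below may be only part of what the source reports. "The series", "measured", "known", "first", "only" and "open" are said of these compounds alone.

Compound 2 `CCN(CC)CC(=O)OC1CC2(N3CCCCC3)CC(c3ccccc3)C1C(c1ccccc1)C2` was examined in an ADME assay on L6 cells (Rattus norvegicus) for cytotoxicity, read by resazurin assay, with a stated time of 72 h (a higher number here means a weaker inhibitor, a lower number a stronger inhibitor), where compound 2 gives 23900 nM. Among the three compounds measured, compound 2 stands lowest: compound 3 `CCN(CC)CC(=O)OC1CC2(N3CCCC3)CC(c3ccccc3)C1C(c1ccccc1)C2` gives 49000 nM, and compound 1 `CN1CCN(CC(=O)NC2CC3(N4CCCC4)CC(c4ccccc4)C2C(c2ccccc2)C3)CC1` gives 50200 nM, the two lying at a similar distance above compound 2. The step of a 2.1-fold higher number from compound 2 to compound 3 (0.31 log units; beyond the scatter) exchanges one saturated amine ring for another, while a 1.0-fold lower number from compound 1 to compound 3 (0.01 log units; within the scatter) shows that swapping the whole acylated side chain leaves the number essentially unchanged. Compound 4 `NC1CC2(N3CCCCC3)CC(c3ccccc3)C1C(c1ccccc1)C2` has not yet been measured in this assay. It differs from compound 2 in one place: amino in place of (((diethylamino)methyl)carbonyl)oxy on a saturated ring carbon. For the measured compounds named here, the closest precedent is a 1.0-fold lower number from compound 1 to compound 3 (0.01 log units; within the scatter), in which a different side chain altered nothing beyond the scatter, so a step of at most modest size in this assay is expected, in either direction. Compound 4 is therefore estimated to give 30000 nM, with a range from 10000 nM to 90000 nM, which would mean an expected step of a 1.3-fold higher number from compound 2 to compound 4 (0.10 log units; within the scatter).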

Compound 4, half-maximal inhibitory concentration: 35000 nM
Compound 4: middle estimate off by 1.2-fold (0.07 log units), on the low side; low and high end bracket the measured number.
By their numbers in this assay, from the lowest: compounds 2, 4, 3 and 1 (each within the scatter of the next, the first and the last beyond it).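

In this assay, a 1.5-fold higher number from compound 2 to compound 4 (0.17 log units; within the scatter), so this saturated ring carbon accepts the change from (((diethylamino)methyl)carbonyl)oxy, with 9 heavy atoms, to amino, with 1, without a shift beyond the scatter. The earlier step from compound 1 to compound 3 only exchanged one acylated side chain for another, whereas compound 4 carries no carbonyl or tertiary side-chain amine at this position, and neither proves necessary to keep the number in this range. No evidence is available to explain this flat response.

On these data alone, it remains open whether a carboxylic acid or a longer alkyl chain at this ring carbon would also leave the number within the scatter. As far as these compounds go, it is also open whether amino would behave the same way with pyrrolidin-1-yl in place of piperidin-1-yl.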